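From fluorophenyl to dimethylaminophenyl in a cell assay

This account rests on a few compounds, and the source may have more. Where it says the series, first, only, none or still open, it means among the compounds named here.

Compound 1 `NC1CCc2nc(-c3ccncc3)nc(Nc3ccc(F)cc3)c2C1` gives 12300 nM in a functional assay on A-375 cells (Homo sapiens) for antiproliferative activity, read by MTT assay, with a stated time of 72 h; a lower number here means a stronger inhibitor, a higher number a weaker inhibitor
Compound 2 `NC1CCc2nc(-c3ccncc3)nc(Nc3cccc(F)c3)c2C1` gives 9900 nM in this assay
Compound 3 `N[C@@H]1CCc2nc(-c3ccncc3)nc(Nc3cccc(F)c3)c2C1` gives 10800 nM in this assay

Compound 2 stands level with compound 1 and compound 3, and all three values lie within the usual scatter of one another. Compound 4 `CN(C)c1ccc(Nc2nc(-c3ccncc3)nc3c2CC(N)CC3)cc1` brings a new group: 4-(dimethylamino)phenyl in place of 3-fluorophenyl on a nitrogen on an aromatic ring and the rest stays the same. Going by the values given here, the only measured step at this place is a 1.2-fold lower number from compound 1 to compound 2 (0.09 log units; within the scatter) and it merely moves a fluorine. The step of a 1.1-fold higher number from compound 2 to compound 3 (0.04 log units; within the scatter) concerns only the drawn configuration the fact that one of compounds 2 and 3 is drawn with a defined configuration and the other without, at the place where they differ and leaves this group untouched. Going by these compounds, the step expected in this assay is a 1.1-fold lower number from compound 2 to compound 4 (0.04 log units; within the scatter) and so none beyond the scatter, though the new group is untested here and the range stays wide. Compound 4 is expected at 9000 nM (estimated range 3500 nM to 20000 nM).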

Compound 4, half-maximal inhibitory concentration: 12600 nM
Compound 4: middle estimate off by 1.4-fold (0.15 log units), on the low side; measured number inside the range.
By their numbers in this assay, from the lowest: compounds 2, 3, 1 and 4 (each within the scatter of the next).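

In this assay the swap to 4-(dimethylamino)phenyl gives a 1.3-fold higher number from compound 2 to compound 4 (0.10 log units; within the scatter) and dimethylamino in place of fluoro on the same aromatic carbon gives a 1.0-fold higher number from compound 1 to compound 4 (0.01 log units; within the scatter) with the rest of the molecule unchanged. So this place, until now probed only by moving a fluorine, also takes a group with a nitrogen and a hydrogen-bond acceptor, with no step beyond the scatter. Nothing available gives a cause for this flat result. Still open, going by these compounds, is whether a carboxylic acid or a longer chain here would give a step beyond the scatter.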